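The source may hold more compounds than are shown below. What is called first, only, known or untested is meant among the compounds shown, and "the series" means these compounds.

Compound 1 `COC(=O)c1c(-c2ccc(OCc3ccccc3)cc2)oc2ccccc2c1=O` and compound 2 `COC(=O)c1c(-c2ccc(OCc3ccccc3)cc2)oc2ccc(OC)cc2c1=O` share one core; compound 3 `COc1cc(-c2oc3ccccc3c(=O)c2C(=O)O)cc(OC)c1OC` and compound 4 `COc1cc(OC)cc(-c2oc3ccccc3c(=O)c2C(=O)O)c1` share another, and the difference between the two cores is not broken down here. In a functional assay on HT-29 cells (Homo sapiens) for cytotoxicity, read by MTT assay, with a stated time of 6 days (on this read-out higher numbers stand for an effect only at larger amounts of compound and lower numbers for an effect already at smaller amounts), compound 2 gives 15.6 ug/mL. For compound 1 the read-out in this assay is only a limit, > 25 ug/mL. For compound 3 the read-out in this assay is likewise a limit, > 25 ug/mL.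

The change from compound 2 to compound 1 is hydrogen in place of methoxy on an aromatic carbon and brings an at least 1.6-fold higher number from compound 2 to compound 1 (0.20 log units; that floor lies within the scatter); the floor of that step is set by the limit of > 25 ug/mL in this assay, at which 2 of the 3 values shown sit. The change from compound 3 to compound 4 is hydrogen in place of methoxy on an aromatic carbon, the same kind of change but not the same: in the first pair the carbon is part of a fused or bridged system of two rings, meta to a fused ring and para to a fused ring, whereas in the second it is ortho to two methoxy groups and para to a large group.

The expectation for compound 4 rests on compound 3 sitting at a limit, > 25 ug/mL. For the measured compounds named here, it also rests on the single measured instance of this kind of change, an at least 1.6-fold higher number from compound 2 to compound 1 (0.20 log units; that floor lies within the scatter), which did not move toward lower numbers. The step from compound 3 to compound 4 in this assay is therefore estimated at a step that the limit leaves unreadable from compound 3 to compound 4, most likely ending again at a limit. In this assay compound 4 is estimated at 40 ug/mL, within 15 ug/mL to 120 ug/mL.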

Compound 4, concentration for half-maximal effect: > 25 ug/mL
Compound 4: a limit, no number; the forecaster's own chance of this, stated with the estimate: 85%; the middle value lies beyond the limit too.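

No step can be read from compound 3 to compound 4 in this assay, because both read-outs are limits and neither gives a number: the limit of > 25 ug/mL in this assay, at which 3 of the 4 values shown sit.

The compounds shown leave open how far replacing methoxy with hydrogen moves the read-out on the core of compound 3, and whether it does so in the same direction as between compound 2 and compound 1.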